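The source may hold more compounds than are shown below. What is called first, only, known or untested is meant among the compounds shown, and "the series" means these compounds.

Measured in a functional assay on ECa-109 cells (Homo sapiens) for antiproliferative activity, read by MTT assay, with a stated time of 72 h; on this read-out higher numbers stand for weaker inhibition and lower numbers for stronger inhibition:
compound 1, `CCCSc1nc(N/N=C/c2ccc(C)cc2)c2nnn(Cc3ccccc3)c2n1`: > 64000 nM, a limit of the assay
compound 2, `CCCSc1nc(N/N=C(\C)c2ccccc2O)c2nnn(Cc3ccccc3Cl)c2n1`: > 64000 nM, a limit of the assay
compound 3, `CCCSc1nc(N/N=C(\C)c2ccccc2O)c2nnn(Cc3cccc(Cl)c3)c2n1`: 13000 nM

Compound 1 stands at the top of the series with no number of its own: in this assay compound 1 gives > 64000 nM, which is a limit of the assay and not a measured value. Compound 2 likewise gives > 64000 nM, again a limit. Only compound 3 gives a number, 13000 nM. Within the data shown here, the one step that can be sized is an at least 4.9-fold lower number from compound 2 to compound 3 (0.69 log units; beyond the scatter); it concerns the chloro position on the benzyl arm and says nothing about the hydrazone end of the molecule. The whole picture is shaped by the limit of > 64000 nM in this assay, at which 2 of the 3 values shown sit.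

The step to compound 4, `CCCSc1nc(N/N=C/c2ccc(Br)cc2)c2nnn(Cc3ccccc3)c2n1`, is bromo in place of methyl on an aromatic carbon. Among the measured compounds shown here, no measured step bears on this change, and compound 1 itself offers only a limit to start from. The expectation for compound 4 in this assay therefore rests on little: a value near the limit, most likely another limit, with no direction beyond the scatter claimed. Compound 4 is thus expected to give about 80000 nM, in a range from 20000 nM to 300000 nM. This expectation amounts to an estimated step that the limit leaves unreadable from compound 1 to compound 4.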

Compound 4, half-maximal inhibitory concentration: > 64000 nM
Compound 4: only a limit was reported; the forecaster's own chance of this, stated with the estimate: 70%; the middle value is on the limit's open side.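

In this assay compound 4 gives > 64000 nM, a limit of the assay. Compound 1 also stands at a limit, and no step can be read between compound 1 and compound 4. Whether bromo in place of methyl alters inhibition at all stays open: the limit of > 64000 nM in this assay, at which 3 of the 4 values shown sit.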